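This account rests on a few compounds, and the source may have more. Where it says the series, first, only, none or still open, it means among the compounds named here.

Series notes. Compound 1 `c1ccc(CNc2ccnc(Nc3ccccc3)n2)cc1` and compound 2 `Clc1ccc(Nc2nccc(NCc3ccccc3)n2)cc1` share one core; compound 3 `Cn1cnc2c(NCc3ccccc3)nc(Nc3ccccc3)nc21` and the unmeasured compound 4 `Cn1cnc2c(NCc3ccccc3)nc(Nc3ccc(Cl)cc3)nc21` share another; the difference between the two cores is not broken down here. Compound 2 differs from compound 1 by chloro in place of hydrogen on an aromatic carbon and compound 4 differs from compound 3 by chloro in place of hydrogen on an aromatic carbon; the place of the change is described in the same words for both pairs, so this is the same change made twice among the four compounds.

In an ADME assay on C2C12 cells (Mus musculus) for cytotoxicity (on this read-out higher numbers stand for lower toxicity in this test and lower numbers for higher toxicity in this test), compound 1 gives only a limit of the assay, > 10000 nM. In this assay compound 2 likewise gives only a limit, > 10000 nM. The step that the two limits leave unreadable from compound 1 to compound 2 is for that reason not readable in size. Compound 3 also gives only a limit in this assay, > 10000 nM. What the three measured compounds have in common is the limit of > 10000 nM in this assay, at which 3 of the 3 values shown sit.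

For compound 4 the same change is expected to leave the read-out where it was. The step that the limit leaves unreadable from compound 3 to compound 4 is expected to stay within the scatter. That rests on the step that the two limits leave unreadable from compound 1 to compound 2, which showed no readable movement, and on (the limit of > 10000 nM in this assay, at which 3 of the 3 values shown sit). On that basis compound 4 is estimated at 15000 nM in this assay, most likely reported again only as a limit, with a range from 6000 nM to 40000 nM.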

Compound 4, half-maximal cytotoxic concentration: > 10000 nM
Compound 4 was reported as a limit; the forecaster's own chance of this, stated with the estimate: 80%; the middle value does not contradict the limit.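

In this assay, among the compounds shown here, compound 4 gives only a limit, > 10000 nM, and compound 3 also stands at a limit, so no step between compound 3 and compound 4 can be read in size. The series shares one result: the limit of > 10000 nM in this assay, at which 4 of the 4 values shown sit.

The compounds shown leave open how far any of the four lies past that limit, and whether chloro in place of hydrogen on an aromatic carbon moves the read-out on either core.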